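From a Chloropropanamide to a Cyclopropyl Urea

A few compounds are considered here, and "the series" means these few. Any claim that something is new, unique, unknown or untested is made for them only; others in the source may bear on it.

Three sulfonate esters built on one shared core have been tested in a functional assay on M21 cells (Homo sapiens) for antiproliferative activity, read by sulforhodamine B assay, with a stated time of 48 h; a lower number here means a stronger inhibitor, a higher number a weaker inhibitor. Compound 1 `CCC(=O)Nc1ccc(S(=O)(=O)Oc2ccccc2I)cc1` gives 11000 nM, compound 2 `CC(C)c1ccccc1OS(=O)(=O)c1ccc(NC(=O)CCCl)cc1` gives 14000 nM, and compound 3 `O=C(CCCl)Nc1ccc(S(=O)(=O)Oc2ccccc2I)cc1` gives 12000 nM. Compound 3 stands within the scatter of both neighbours: the change a 1.1-fold higher number from compound 1 to compound 3 (0.04 log units; within the scatter) and the change a 1.2-fold lower number from compound 2 to compound 3 (0.07 log units; within the scatter) are each too small to count. Compound 4 `O=C(Nc1ccc(S(=O)(=O)Oc2ccccc2I)cc1)NC1CC1` differs from compound 3 by cyclopropylamino in place of 2-chloroethyl on a carbonyl carbon. Among the compounds with values here, no measured step exchanges the amide side chain for a urea, so only the indifference of the chain to chlorination in the step from compound 1 to compound 3 hints at what to expect. Compound 4 is therefore estimated at 12000 nM, with a range of 4000 nM to 36000 nM. The step of no change at the digits printed from compound 3 to compound 4 (within the scatter) is expected to remain within the scatter.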

Compound 4, half-maximal inhibitory concentration: 11000 nM
Beside the measured number, compound 4's estimate is 1.1-fold (0.04 log units) above it; the measured number falls inside the stated range.
By their numbers in this assay, from the lowest: compounds 1, 4, 3 and 2 (each within the scatter of the next).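

Replacing the side chain with a urea in this assay gives a 1.1-fold lower number from compound 3 to compound 4 (0.04 log units; within the scatter) and no change at the digits printed from compound 1 to compound 4 (within the scatter) even though a ring and a hydrogen-bond donor enter at this carbonyl carbon. Ethyl, 2-chloroethyl and cyclopropylamino therefore all sit within the scatter here, so this position has shown no response even to a change larger than chlorination. Nothing available explains this indifference. On these data alone, whether a carboxylic acid, an amine or a much longer chain at this carbonyl carbon would move the number remains open.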